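Phenyl in Place of Isopropyl: Expected Outcome for Compound 4

This account rests on a few compounds, and the source may have more. Where it says the series, first, only, none or still open, it means among the compounds named here.

Compound 1 `Cc1cc(NC(=O)Cn2nnc(-c3ccccc3)n2)n(C(C)C)n1` was tested in an assay on HEK293 cells for activation of Kir3.1/Kir3.2 (Homo sapiens), read by thallium flux (on this read-out higher numbers stand for an effect only at larger amounts of compound and lower numbers for an effect already at smaller amounts), where compound 1 gives 556 nM. Compound 2 `CC1CC1c1cc(NC(=O)Cn2nnc(-c3ccccc3)n2)n(C2CCCCC2)n1` gives 843 nM in this assay, a number lying within the usual scatter of that of compound 1, so neither can be set above the other. Compound 3 `O=C(Cn1nnc(-c2ccccc2)n1)Nc1cc(C2(C(F)(F)F)CC2)nn1C1CCCCC1` is reported in this assay as "not active" (no number reported), with no number attached. Compound 4 `Cc1cc(NC(=O)Cn2nnc(-c3ccccc3)n2)n(-c2ccccc2)n1` has not been measured. It differs from compound 1 by phenyl in place of isopropyl on an aromatic nitrogen. Among the measured compounds shown here, no measured pair shows this change, so its direction is open; a modest step is expected because compound 2, carrying cyclohexyl, still gives 843 nM. The step of a 1.4-fold higher number from compound 1 to compound 4 (0.16 log units; within the scatter) is expected to stay close to the scatter. Compound 4 is estimated at 800 nM, within 200 nM to 4000 nM.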

Compound 4, half-maximal effective concentration: 3020 nM
Compound 4: middle estimate off by 3.8-fold (0.58 log units), on the low side; the measured number falls inside the stated range.
By their numbers in this assay, from the lowest: compounds 1 and 2 (each within the scatter of the next); then compound 4.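

In this assay, among the compounds shown here, phenyl in place of isopropyl on an aromatic nitrogen gives a 5.4-fold higher number from compound 1 to compound 4 (0.73 log units; beyond the scatter), the first step at this position read with the rest of the molecule unchanged. It shows that, with the methyl group kept, the number responds to this exchange beyond the scatter. No evidence at hand accounts for the step. From the compounds shown here alone, whether a benzyl group or a phenyl ring bearing an amine would stay closer to compound 1 remains open. So does whether the exchange has the same effect without the methyl group.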